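This account rests on a few compounds, and the source may have more. Where it says the series, first, only, none or still open, it means among the compounds named here.

Compound 1 `C=C[C@@](C)(/C=C/c1ccc(OS(=O)(=O)C(F)(F)F)cc1)CCC=C(C)C` carries a ((trifluoromethyl)sulfonyl)oxy group on the aromatic ring of the shared core. In an ADME assay on HEK293 cells (Homo sapiens) for cytotoxicity, with a stated time of 72 h (a higher number here means that more compound is needed for the effect, a lower number that less compound is needed), compound 1 gives > 36600 nM, which is a limit of the assay and not a number. Compound 2 `C=C[C@@](C)(/C=C/c1ccc(OS(=O)(=O)c2ccc(C)cc2)cc1)CCC=C(C)C` gives in this assay > 36600 nM, likewise a limit. Compound 3 `C=C[C@@](C)(/C=C/c1ccc(O)cc1)CC/C=C/C(=O)c1ccccc1` gives in this assay > 36600 nM, again a limit. Compound 1 thus stands only at a limit, as do the other two measured compounds, since (the limit of > 36600 nM in this assay, at which 3 of the 3 values shown sit). Among the compounds with values here, the single step between measured compounds differing in one place, a step that the two limits leave unreadable from compound 1 to compound 2, cannot be read for the same reason. Compound 4 `C=C[C@@](C)(/C=C/c1ccc(-c2ccc(F)cc2)cc1)CCC=C(C)C` differs from compound 1 by 4-fluorophenyl in place of ((trifluoromethyl)sulfonyl)oxy on an aromatic carbon. Within the data shown here, no measured step bears on this change with a readable size, and the only step, from compound 1 to compound 2, gives no direction. The expectation is that compound 4 also sits at or near the limit, the step that the limit leaves unreadable from compound 1 to compound 4 being expected to stay within the scatter. For compound 4 a value of 40000 nM is estimated, in the range 15000 nM to 100000 nM.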

Compound 4, half-maximal effective concentration: > 36600 nM
Compound 4 gave a limit, no number (the forecaster's own chance of this, stated with the estimate: 75%); the middle value does not contradict the limit.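

In this assay compound 4 gives > 36600 nM, a limit and not a number. No step from compound 1 to compound 4 can therefore be read: the limit of > 36600 nM in this assay, at which 4 of the 4 values shown sit.

The compounds shown leave open whether any change on the shared core gives a readable value in this assay.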